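Moving a fluorine on the ring of compound 2

The source may report more compounds than this note shows. Statements on the series, on what has been measured and on what is new or still open speak of the compounds shown alone.

Compound 2 `CC(C)(C)C(=O)N(CCCCCCN1C[C@H](O)[C@@H](O)[C@H](O)[C@H]1CO)c1ccc(F)cc1F` is one of two compounds that have been measured in an ADME assay on MDBK cells (Bos taurus) for cytotoxicity, read by MTT assay; a lower number here means that less compound is tolerated, a higher number that more compound is tolerated. In this assay compound 2 reaches only the assay's limit, > 500000 nM. Compound 1 `CC(C)(C)C(=O)N(CCCCCCN1C[C@H](O)[C@@H](O)[C@H](O)[C@H]1CO)C1CCCCC1` likewise stops at the limit, > 500000 nM. The step that the two limits leave unreadable from compound 1 to compound 2 can therefore not be read, since both values sit at the limit of > 500000 nM in this assay, at which 2 of the 2 values shown sit. Compound 3 `CC(C)(C)C(=O)N(CCCCCCN1C[C@H](O)[C@@H](O)[C@H](O)[C@H]1CO)c1cc(F)ccc1F` differs from compound 2 by 2,5-difluorophenyl in place of 2,4-difluorophenyl on an amide-type nitrogen. Among the measured compounds shown here, no measured step bears on this change, and compound 3 is expected to remain at the limit as well, the expected step being a number no higher from compound 2 to compound 3 (the limit leaves the size open). Compound 3 is thus estimated at 500000 nM, between 250000 nM and 1000000 nM.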

Compound 3, half-maximal cytotoxic concentration: > 500000 nM
Compound 3 gave a limit, no number (the forecaster's own chance of this, stated with the estimate: 90%); the middle value sits exactly at the limit.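

In this assay, compound 1, compound 2 and compound 3 all stop at a limit rather than a number, so no step between them can be read: the limit of > 500000 nM in this assay, at which 3 of the 3 values shown sit.

The compounds shown leave open at what concentration any of the three would harm these cells, and whether the groups on the amide-type nitrogen differ in this respect.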